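The source may hold more compounds than are shown below. What is called first, only, known or untested is meant among the compounds shown, and "the series" means these compounds.

Measured in a functional assay on the whole organism for inhibition, with Rattus norvegicus as the target, at a dose of 30 mg/kg; a higher number here means more inhibition at the dose given (going by the name of the read-out), a lower number less inhibition:
Compound 1 `Cc1ccc(-c2nc3ncccc3o2)cc1` gives 5%.
Compound 2 `N#Cc1cccc(F)c1-c1nc2ncccc2o1` gives 50%.
Compound 3 `Fc1ccc(-c2nc3cccnc3o2)cc1` gives 27%.

Compound 1 stands lowest of the three numbers. Its nearest neighbour is compound 3, higher by a margin beyond the scatter, and compound 2 lies furthest above it, also beyond the scatter. The step to compound 4 `Clc1ccc(-c2nc3ncccc3o2)cc1` alters a single group: chloro in place of methyl on an aromatic carbon. Among the measured compounds shown here, no step between measured compounds touches this group, so the direction rests on nothing measured. A step within the scatter, or at most a modest rise, is expected in this assay. The step expected a number 10 percentage points higher from compound 1 to compound 4 (within the scatter) is small. Compound 4 is estimated at 15%, within a range of 0% to 40%.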

Compound 4, a percentage reported as inhibition, in the whole organism at one dose (the size of the read-out at that dose, not a potency): 24%
Beside the measured number, compound 4's estimate is 9 percentage points below it; low and high end bracket the measured number.
By their numbers in this assay, from the lowest: compound 1; then compounds 4 and 3 (each within the scatter of the next); then compound 2.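

Chloro in place of methyl on the aromatic carbon gives the first measured step at this position in this assay: a number 19 percentage points higher from compound 1 to compound 4 (beyond the scatter). The read-out therefore responds to the group held here, even though the heavy-atom count stays the same and neither group has a hydrogen-bond donor, hydrogen-bond acceptor or net charge. No measured property of either group bears on this step.

From the compounds shown here alone, whether a methoxy group, an amine or a carboxylic acid at this position would raise or lower the number remains open. Going by these compounds, whether a second step here would follow the same direction also remains open.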